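From Phenyl to Methoxy on a Shared Core

The compounds below may be only part of what the source reports. "The series", "measured", "known", "first", "only" and "open" are said of these compounds alone.

Compound 1 `CC(=O)c1cccc(Nc2ccnc(SCC(=O)c3ccc(-c4ccccc4)cc3)n2)c1` was tested in a functional assay on CAKI-1 cells (Homo sapiens) for inhibition, read by sulforhodamine B assay, with a stated time of 48 h, tested at 10 uM (on this read-out higher numbers stand for more inhibition of growth at the one concentration tested and lower numbers for less inhibition of growth), and gave 23%. Of the two numbers shown it stands first, yet the gap to compound 2 `CCOC(=O)c1ccc(Nc2ccnc(SCC(=O)c3ccc([N+](=O)[O-])cc3)n2)cc1`, which in this assay gave 16%, lies within the scatter, so the two cannot be told apart. Compound 3 `COc1ccc(C(=O)CSc2nccc(Nc3cccc(C(C)=O)c3)n2)cc1` has not yet been measured; it differs from compound 1 in one place (methoxy in place of phenyl on an aromatic carbon). For the measured compounds named here, no measured pair shows this change, so the expected step is a number 5 percentage points lower from compound 1 to compound 3 (within the scatter), nothing beyond the scatter in either direction. For compound 3 the estimated result in this assay is 18%, between 5% and 33%.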

Compound 3, percent growth inhibition at one concentration: 35%
The estimate for compound 3 lay 17 percentage points below the measured number, outside the stated range (above it).
By their numbers in this assay, from the lowest: compounds 2 and 1 (each within the scatter of the next); then compound 3.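

In this assay, for the compounds shown here, methoxy in place of phenyl gives a number 12 percentage points higher from compound 1 to compound 3 (beyond the scatter), the first step here that clears the scatter. This position, para to a large group, therefore does not need the second aromatic ring for growth inhibition: the group with 2 heavy atoms gives a higher number than the one with 6. Nothing measured here gives a reason for the rise.

From the compounds shown here alone, whether the oxygen matters, or only the loss of the ring, stays open. A hydroxyl, an amine or a plain methyl at this place could separate the two readings.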